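This account rests on a few compounds, and the source may have more. Where it says the series, first, only, none or still open, it means among the compounds named here.

Compound 1 `CCS(=O)(=O)N(Cc1cccnc1)c1cccc(C(=O)c2ccccc2)c1` gives 1100 nM in an assay on isolated protein with metabotropic glutamate receptor 2 (Homo sapiens) as the target; on this read-out lower numbers stand for an effect already at smaller amounts and higher numbers for an effect only at larger amounts of compound; this is the lowest of the three numbers, though compound 2 `CCS(=O)(=O)N(Cc1cccnc1)c1ccc(Cc2ccccc2)cc1` with 1600 nM and compound 3 `CCS(=O)(=O)N(Cc1cccnc1)c1ccc(COc2ccccc2)cc1` with 2100 nM both lie within the scatter of it. Compound 4 `CCS(=O)(=O)N(Cc1cccnc1)c1cccc(Oc2ccccc2)c1` differs from compound 1 by phenoxy in place of benzoyl on an aromatic carbon. Among the compounds with values here, the only measured step with a related exchange is a 1.3-fold higher number from compound 2 to compound 3 (0.12 log units; within the scatter), where phenoxy enters on a saturated chain carbon bound to an aromatic carbon rather than on an aromatic carbon, so it bears only loosely on the present change. Taken with the flat spread of the three numbers, no step beyond the scatter is expected in this assay, and the estimated step is a 1.3-fold higher number from compound 1 to compound 4 (0.10 log units; within the scatter). Compound 4 is therefore expected to give 1400 nM, with a range of 600 nM to 3500 nM.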

Compound 4, half-maximal effective concentration: 360 nM
Beside the measured number, compound 4's estimate is 3.9-fold (0.59 log units) above it; measured number below the stated range.
By their numbers in this assay, from the lowest: compound 4; then compounds 1, 2 and 3 (each within the scatter of the next).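

Phenoxy in place of benzoyl on an aromatic carbon, meta to a large group, gives a 3.1-fold lower number from compound 1 to compound 4 (0.49 log units; beyond the scatter), the only step shown that lies beyond the scatter. Within the data shown here, the related exchange on a saturated chain carbon, a 1.3-fold higher number from compound 2 to compound 3 (0.12 log units; within the scatter), stayed within the scatter, so the new step is the first sign that the series responds to a change of this kind. Nothing available explains the step.

From the compounds shown here alone, whether the lower number is specific to the ether oxygen remains open. A thioether or a secondary amine linking the same phenyl, or a fluoro or methoxy group on the phenoxy ring, would test this.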